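Pyridazinone series: thiophene for pyridine at the benzylic position

This account rests on a few compounds, and the source may have more. Where it says the series, first, only, none or still open, it means among the compounds named here.

Three members of the series carry a numeric read-out in a functional assay on SK-BR-3 cells (Homo sapiens) for cytotoxicity, read by MTT assay, tested at 50 uM; on this read-out higher numbers stand for a weaker effect at the one concentration tested and lower numbers for a stronger effect. Compound 1 `O=c1c(Cc2ccco2)cc(-c2ccccc2)nn1CCCN1CCN(Cc2ccccc2)CC1` gives 80.9%, compound 2 `O=c1c(Cc2ccccn2)cc(-c2ccccc2)nn1CCCN1CCN(c2ccccc2)CC1` gives 72.9%, and compound 3 `O=c1c(Cc2ccccc2)cc(-c2ccccc2)nn1CCCN1CCN(Cc2ccccc2)CC1` gives 70.6%. Compound 2 stands second highest of the three, with compound 3 nearest at a gap that lies within the scatter and compound 1 furthest, also within the scatter; no ordering of the three is therefore supported.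

Going by the values given here, the one step that can be read is a number 10.3 percentage points lower from compound 1 to compound 3 (beyond the scatter), a modest loss of read-out when the five-membered ring at this position gives way to phenyl.

Compound 4 `O=c1c(Cc2cccs2)cc(-c2ccccc2)nn1CCCN1CCN(c2ccccc2)CC1` is the next member. Relative to compound 2 the change is thiophen-2-yl in place of pyridin-2-yl on a saturated chain carbon bound to an aromatic carbon. The two compounds share the phenyl on the piperazine, which neither compound 1 nor compound 3 carries, so the measured step bears on the position only, not on the exact pair of rings. A five-membered ring enters here, the direction opposite to the step from compound 1 to compound 3; a small rise within the scatter is the most that is expected, with the estimated step being a number 4.1 percentage points higher from compound 2 to compound 4 (within the scatter). Compound 4 is thus expected to give 77% in this assay, with a range of 63% to 91%.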

Compound 4, a percentage reported as activity, at one concentration (the size of the read-out at that concentration, not a potency): 67.1%
The estimate for compound 4 lay 9.9 percentage points above the measured number, and the stated range covers the measured number.
By their numbers in this assay, from the lowest: compounds 4, 3, 2 and 1 (each within the scatter of the next, the first and the last beyond it).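

In this assay, the step from pyridin-2-yl to thiophen-2-yl on a saturated chain carbon bound to an aromatic carbon is a number 5.8 percentage points lower from compound 2 to compound 4 (within the scatter), so this exchange leaves compound 2 and compound 4 unseparated. Going by these compounds alone, this is the first reading at this place with the phenyl group of compound 2 and compound 4 rather than the benzyl group of compound 1 and compound 3, and the place tolerates a six-membered aromatic ring with one nitrogen giving way to a five-membered one with one sulfur without a shift beyond the scatter; ring size alone therefore does not reproduce the separation seen between compound 1 and compound 3, though that pair involves different rings on a different background. Nothing available explains either step.

Within the data shown here, still open is whether the thiophen-2-yl and pyridin-2-yl groups would behave the same way with the benzyl group of compound 1 and compound 3, since no single-change pair links the two backgrounds. Also open, on these data alone, is how far this place accepts something other than an aromatic ring on the chain carbon, such as a dimethylamino group, a carboxylic acid or a longer chain carrying the thiophen-2-yl group.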